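Series notes: 4-hydroxyphenyl in place of 2-methylphenyl

The source may report more compounds than this note shows. Statements on the series, on what has been measured and on what is new or still open speak of the compounds shown alone.

Measured so far:
Compound 1 `Cc1nc(-c2cccnc2)sc1-c1nnc(-c2ccncc2)o1` — in an ADME assay on HCT-116 cells (Homo sapiens) for cytotoxicity, read by MTT assay (a higher number here means that more compound is tolerated, a lower number that less compound is tolerated), compound 1 gives > 100 ug/mL, a limit of the assay.
Compound 2 `Cc1ccccc1-c1nnc(-c2sc(-c3cccnc3)nc2C)o1` — in this assay compound 2 gives > 100 ug/mL, again a limit.
Compound 3 `Cc1nc(-c2cccnc2)sc1-c1nnc(-c2ccccc2[N+](=O)[O-])o1` — in this assay compound 3 gives > 100 ug/mL, also a limit.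

Compound 2 stands at the limit of > 100 ug/mL in this assay, at which 3 of the 3 values shown sit. Within the data shown here, no compound in the set gives a number rather than a limit, so compound 2 cannot be placed above or below the others. The steps that touch it are a step that the two limits leave unreadable from compound 1 to compound 2 and a step that the two limits leave unreadable from compound 2 to compound 3; both run between two limits and their sizes are not readable. The unmeasured compound 4 `Cc1nc(-c2cccnc2)sc1-c1nnc(-c2ccc(O)cc2)o1` differs from compound 2 as follows: 4-hydroxyphenyl in place of 2-methylphenyl on an aromatic carbon. Neither measured step bears on this change in a readable way, and none of the three measured compounds carries a 4-hydroxyphenyl group. With every value sitting at the limit of > 100 ug/mL in this assay, at which 3 of the 3 values shown sit, no step beyond the scatter is expected in this assay. The estimated step is a number no higher from compound 2 to compound 4 (the limit leaves the size open). For compound 4 the estimate in this assay is 100 ug/mL, with a range from 40 ug/mL to 250 ug/mL, and a limit rather than a number is the more likely report.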

Compound 4, half-maximal cytotoxic concentration: > 100 ug/mL
Compound 4 gave a limit, no number (the forecaster's own chance of this, stated with the estimate: 80%); the middle value lies on the limit itself.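

Compound 4 sits at a limit in this assay, like compound 1 and compound 2, so neither the step from compound 2 to compound 4 nor that from compound 1 to compound 4 can be read: the limit of > 100 ug/mL in this assay, at which 4 of the 4 values shown sit.

No compound shown gives a number, which leaves open whether the groups on the shared core differ at all in this assay.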